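The source may report more compounds than this note shows. Statements on the series, on what has been measured and on what is new or still open speak of the compounds shown alone.

Measured so far:
compound 1 `COc1cc(/C=C/C(=O)c2cccc(-n3cc(-c4ccccc4)[nH]c3=O)c2)cc(OC)c1OC` gives 1100 nM
compound 2 `COc1ccc(-c2cn(-c3cccc(C(=O)/C=C/c4ccc(O)c(OC)c4)c3)c(=O)[nH]2)cc1` gives 2560 nM

In a functional assay on NCI/ADR-RES cells (Homo sapiens) for inhibition (a higher number here means a weaker inhibitor of growth, a lower number a stronger inhibitor of growth), compound 2 stands at the higher of the two numbers, with compound 1 at a lower number, a gap beyond the scatter. Compound 3 `COc1ccc(-c2cn(-c3cccc(C(=O)/C=C/c4cc(OC)c(OC)c(OC)c4)c3)c(=O)[nH]2)cc1` carries 3,4,5-trimethoxyphenyl in place of 4-hydroxy-3-methoxyphenyl on a double-bonded chain carbon bound to a double-bonded chain carbon. Among the compounds with values here, the ring on the double-bonded chain carbon of compound 3 now matches that of compound 1, while the other end of the shared core still differs from compound 1; no measured step covers either change alone. A moderate move downward toward the number of compound 1 is expected, the step from compound 2 to compound 3 estimated at a 2.0-fold lower number from compound 2 to compound 3 (0.29 log units; within the scatter). Compound 3 is expected to give 1300 nM, within 500 nM to 3500 nM.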

Compound 3, concentration for 50% growth inhibition: 1700 nM
Compound 3: middle estimate off by 1.3-fold (0.12 log units), on the low side; the measured number falls inside the stated range.
By their numbers in this assay, from the lowest: compounds 1, 3 and 2 (each within the scatter of the next, the first and the last beyond it).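

In this assay, 3,4,5-trimethoxyphenyl in place of 4-hydroxy-3-methoxyphenyl on a double-bonded chain carbon bound to a double-bonded chain carbon gives a 1.5-fold lower number from compound 2 to compound 3 (0.18 log units; within the scatter), so this exchange is not resolved from repeat measurement. Methoxy in place of hydrogen on an aromatic carbon gives a 1.5-fold higher number from compound 1 to compound 3 (0.19 log units; within the scatter), so neither single change stands beyond the scatter. No measured evidence bears on the size of these steps.

Still open, from the compounds shown here alone, is how an amine or a carboxylic acid in place of that methoxy on an aromatic carbon would read in this assay.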